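A few compounds are considered here, and "the series" means these few. Any claim that something is new, unique, unknown or untested is made for them only; others in the source may bear on it.

Compound 1 `O=C(O)c1nc(N2CCN(C(=O)COc3ccc(Cl)cc3)CC2)c2cc(F)sc2n1` reports in a functional assay on cells (Lymphocyte) (a lower number here means a stronger inhibitor, a higher number a weaker inhibitor), only a limit, > 10000 nM (the limit of > 10000 nM in this assay, at which 1 of the 3 values shown sits). Compound 2 `Nc1nc(N2CCN(C(=O)COc3ccc(Cl)cc3)CC2)c2cc(F)sc2n1` gives 700 nM in this assay, and compound 3 `Nc1nc(N2CCN(C(=O)CCc3ccccc3)CC2)c2cc(F)sc2n1` gives 6990 nM. Two steps connect these compounds: an at least 14-fold lower number from compound 1 to compound 2 (1.15 log units; beyond the scatter), and a 10-fold higher number from compound 2 to compound 3 (1.00 log units; beyond the scatter). Among the two numbers shown, compound 3 stands highest, with compound 2 as its nearest neighbour. Compound 4 `Nc1nc(N2CCN(C(=O)C3CCCCC3)CC2)c2cc(F)sc2n1` has not yet been measured; it differs from compound 3 in one place: cyclohexyl in place of phenethyl on a carbonyl carbon. Among the measured compounds shown here, the step that bears on this change is the one from compound 2 to compound 3, which also altered the group on the carbonyl carbon, by a modest amount. For the measured compounds named here, no measured step tests the exchange of an aromatic ring for a saturated one, so only a modest step is expected here, most likely toward a higher number. Compound 4 is therefore estimated at 9000 nM in this assay, within 2500 nM to 30000 nM, an expected step of a 1.3-fold higher number from compound 3 to compound 4 (0.11 log units; within the scatter).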

Compound 4, half-maximal inhibitory concentration: > 10000 nM
Compound 4 gave a limit, no number; the forecaster's own chance of this, stated with the estimate: 40%; middle value at least 1.1-fold (0.04 log units) away from the limit.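

In this assay compound 4 gives only a limit, the second such result among these compounds: the limit of > 10000 nM in this assay, at which 2 of the 4 values shown sit. With cyclohexyl on the carbonyl carbon the result is an at least 1.4-fold higher number from compound 3 to compound 4 (0.15 log units; that floor lies within the scatter), so this floor does not separate cyclohexyl from phenethyl. The step against the (4-chlorophenoxy)methyl group is an at least 14-fold higher number from compound 2 to compound 4 (1.15 log units; beyond the scatter), which shows that a non-aromatic ring set directly on the carbonyl carbon does not recover the number of compound 2, and compound 2 remains the strongest of the four compounds.

The compounds shown leave open whether the chlorine or the chain oxygen matters more, a question that a phenoxymethyl group without chlorine or a 4-chlorophenethyl group could address. They also leave open how far compound 4 actually lies from compound 3.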